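Adding a Second Chloro to a Benzyl Group

The source may report more compounds than this note shows. Statements on the series, on what has been measured and on what is new or still open speak of the compounds shown alone.

Three compounds have been measured in an ADME assay on HEK-293T cells (Homo sapiens) for antiproliferative activity, read by MTT assay, with a stated time of 48 h, in the presence of a further agent that is not named here; on this read-out higher numbers stand for lower toxicity in this test and lower numbers for higher toxicity in this test:

Compound 1, `Cc1ccc(-c2nn(-c3ccccc3)cc2C(=O)NOCc2ccccc2)cc1`: 40800 nM
Compound 2, `Cc1ccc(-c2nn(-c3ccccc3)cc2C(=O)NOCc2ccccc2Cl)cc1`: 38700 nM
Compound 3, `O=C(NOCc1ccccc1Cl)c1cn(-c2ccccc2)nc1-c1ccc(F)cc1`: 44700 nM

Compound 1 and compound 2 differ by a single change, (chloro in place of hydrogen on an aromatic carbon). This change gave a 1.1-fold lower number from compound 1 to compound 2 (0.02 log units; within the scatter). Compound 3 differs from compound 1 in more than one place, so the difference between the two cores is not broken down here. Between compound 2 and compound 3 the change is fluoro in place of methyl on an aromatic carbon, and the step was a 1.2-fold higher number from compound 2 to compound 3 (0.06 log units; within the scatter). All three numbers therefore lie close together.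

Compound 4, `O=C(NOCc1ccc(Cl)cc1Cl)c1cn(-c2ccccc2)nc1-c1ccc(F)cc1`, has not yet been measured. It differs from compound 3 by chloro in place of hydrogen on an aromatic carbon. For the measured compounds named here, this is the same kind of change as the one from compound 1 to compound 2, but the surroundings differ: in compound 2 the entering chloro sits ortho to a large group, whereas in compound 4 it sits meta to a chloro group and para to a large group. Because a 1.1-fold lower number from compound 1 to compound 2 (0.02 log units; within the scatter) lay within the scatter, the expected step in this assay is small, a 1.1-fold lower number from compound 3 to compound 4 (0.03 log units; within the scatter). Compound 4 is accordingly estimated at 42000 nM, most likely between 24000 nM and 75000 nM.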

Compound 4, half-maximal cytotoxic concentration: 45000 nM
Beside the measured number, compound 4's estimate is 1.1-fold (0.03 log units) below it; low and high end bracket the measured number.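

In this assay, turning the 2-chlorobenzyl group into a 2,4-dichlorobenzyl group gave a 1.0-fold higher number from compound 3 to compound 4 (0.00 log units; within the scatter). Set beside the earlier addition of a chloro to the benzyl ring on the other core, the two steps agree: the same change on two cores in this assay, a 1.1-fold lower number (0.02 log units; within the scatter) from compound 1 to compound 2 and a 1.0-fold higher number (0.00 log units; within the scatter) from compound 3 to compound 4, 1.1-fold (0.03 log units) apart, within the scatter of two such steps This shows that in these two cases, the added chloro changed the number by no more than the scatter on either core, even though it entered a different place on the ring each time, but two pairs cannot show that the same would hold on a third core or in a different test.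

Still open, from the compounds shown here alone, is whether a different group at this place on the benzyl ring, such as a methoxy group, an amine or a carboxylic acid, would give a step beyond the scatter. Also open, going by these compounds, is how the chloro step would read on a core whose number sits much lower in this test, where higher toxicity would leave more room to see a change.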